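Dropping the Cyano from the Cyclopropyl Sulfonamide

The source may hold more compounds than are shown below. What is called first, only, known or untested is meant among the compounds shown, and "the series" means these compounds.

Compound 1 `COc1ccc2c(OCC[C@@H]3NC(=O)N(C)CCCC/C=C\[C@@H]4C[C@@]4(C(=O)NS(=O)(=O)C4(F)CC4)NC3=O)cc(-c3nc(C(C)C)cs3)nc2c1Cl` gives 51400 nM in an ADME assay on cells (Homo sapiens) for activation (a lower number here means that less compound is tolerated, a higher number that more compound is tolerated), and compound 2 `COc1ccc2c(OCC[C@@H]3NC(=O)N(C)CCCC/C=C\[C@@H]4C[C@@]4(C(=O)NS(=O)(=O)C4(C)CC4)NC3=O)cc(-c3nc(C(C)C)cs3)nc2c1Cl` gives 37400 nM. Compound 3 `COc1ccc2c(OCC[C@@H]3NC(=O)N(C)CCCC/C=C\[C@@H]4C[C@@]4(C(=O)NS(=O)(=O)C4(C#N)CC4)NC3=O)cc(-c3nc(C(C)C)cs3)nc2c1Cl` reaches only a limit of this assay, > 75000 nM, which is the limit of > 75000 nM in this assay, at which 1 of the 3 values shown sits. So compound 3 stands at the upper edge of what has been measured, with only a floor and no exact number. Compound 4 `COc1ccc2c(OCC[C@@H]3NC(=O)N(C)CCCC/C=C\[C@@H]4C[C@@]4(C(=O)NS(=O)(=O)C4CC4)NC3=O)cc(-c3nc(C(C)C)cs3)nc2c1Cl` differs from compound 3 by hydrogen in place of cyano on a saturated ring carbon. Two earlier exchanges at this same saturated ring carbon bear on it: an at least 1.4-fold higher number from compound 1 to compound 3 (0.16 log units; that floor lies within the scatter) and an at least 2.0-fold higher number from compound 2 to compound 3 (0.30 log units; that floor lies within the scatter), both within the scatter, as was a 1.4-fold lower number from compound 1 to compound 2 (0.14 log units; within the scatter). A step no larger than the scatter is therefore expected: an at least 1.2-fold lower number from compound 3 to compound 4 (0.09 log units; that floor lies within the scatter). Compound 4 is estimated at 60000 nM, with a range from 30000 nM to 120000 nM.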

Compound 4, half-maximal cytotoxic concentration: 40400 nM
Estimate against measurement, compound 4: 1.5-fold (0.17 log units) above, within the range that was stated.
By their numbers in this assay, from the lowest: compounds 2, 4 and 1 (each within the scatter of the next). At a limit, above all of these: compound 3.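

Hydrogen leaves this saturated ring carbon with no substituent at all, and in this assay that cannot be told apart from methyl or fluoro: a 1.1-fold higher number from compound 2 to compound 4 (0.03 log units; within the scatter) and a 1.3-fold lower number from compound 1 to compound 4 (0.10 log units; within the scatter). Going by these compounds, removing the cyano gives an at least 1.8-fold lower number from compound 3 to compound 4 (0.26 log units; that floor lies within the scatter), so the true size of this step remains unknown. Compound 3 still has only a limit, not a number: the limit of > 75000 nM in this assay, at which 1 of the 4 values shown sits.

On these data alone, whether a bulkier ethyl, a phenyl or a carboxylic acid on this carbon would shift the tolerated concentration stays open. Also open, as far as these compounds go, is how far the cyano of compound 3 really sets it apart from the others.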